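A few compounds are considered here, and "the series" means these few. Any claim that something is new, unique, unknown or untested is made for them only; others in the source may bear on it.

Measured so far:
- compound 1, `Cc1cc(OC(=O)C(C)(C)CCC(CO[N+](=O)[O-])O[N+](=O)[O-])n(-c2ccccc2)n1`: 10 h
- compound 2, `Cc1cc(OC(=O)c2ccc(OCCCO[N+](=O)[O-])cc2)n(-c2ccccc2)n1`: 35 h
- compound 3, `Cc1cc(OC(=O)C(C)(C)CO[N+](=O)[O-])n(-c2ccccc2)n1`: 1.9 h

Within a physicochemical assay for metabolic stability, read by HPLC (on this read-out lower numbers stand for a shorter-lived compound and higher numbers for a longer-lived compound), compound 2 has the highest number of the three; compound 1 sits at a lower number beyond the scatter, and compound 3 lower still, also beyond the scatter. All three share the same core and differ only in the ester portion carrying the nitrooxy chain.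

The next compound in the series is compound 4, `Cc1cc(OC(=O)c2ccc(OCC(CO[N+](=O)[O-])O[N+](=O)[O-])cc2)n(-c2ccccc2)n1`, which has not yet been measured in this assay. Compared with compound 2 the change is:

nitrooxy in place of hydrogen on a saturated chain carbon bound to two saturated chain carbons

Among the measured compounds shown here, no measured pair in the set isolates this single change, so the direction has to be taken from the spread of the three numbers. Compound 1 and compound 3 show that the chain bearing the nitrooxy groups does move the half-life, but they do not separate the effect of one more nitrooxy from the rest of the ester. The expected step from compound 2 to compound 4 is a moderate decrease, a 1.6-fold lower number from compound 2 to compound 4 (0.20 log units; within the scatter), with a range that keeps no change beyond the scatter as possible. For compound 4 the estimate in this assay is 22 h, between 9 h and 55 h.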

Compound 4, half-life: 25 h
Compound 4: the middle estimate sits 1.1-fold (0.06 log units) below what was measured, within the range that was stated.
By their numbers in this assay, from the lowest: compound 3; then compound 1; then compounds 4 and 2 (each within the scatter of the next).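

In this assay, among the compounds shown here, the first comparison that differs in one place reads a 1.4-fold lower number from compound 2 to compound 4 (0.15 log units; within the scatter), so nitrooxy in place of hydrogen on a saturated chain carbon bound to two saturated chain carbons does not separate the two compounds beyond the scatter. Compound 1 and compound 3 differ from compound 2 in more than one place and could not speak to this position, whereas this pair shows that 3-(nitrooxy)propyl and 2,3-bis(nitrooxy)propyl are not distinguished on this read-out. Nothing available gives a reason for this result.

As far as these compounds go, whether a hydroxyl or an amine at this carbon, or a longer chain carrying the nitrooxy, would behave the same stays open. This pair also speaks only to this chain, so it carries nothing over to the chains of compound 1 and compound 3.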